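The source may report more compounds than this note shows. Statements on the series, on what has been measured and on what is new or still open speak of the compounds shown alone.

Measured compounds:
- compound 1, `COc1cc2c(cc1OC)C(CC(=O)Nc1cccc(Cl)c1)CC2`, 28%
- compound 2, `COc1cc2c(cc1OC)C(CC(=O)Nc1ccc(Cl)cc1)CC2`, 63%
- compound 3, `COc1cc2c(cc1OC)C(CC(=O)Nc1ccc(Br)cc1)CC2`, 40%

These three compounds share one core and differ only in the aryl group on the amide nitrogen. In a functional assay on the whole organism (strain Wistar) for inhibition, with Rattus norvegicus as the target, read by paw edema, with a stated time of 2 h, at a dose of 100 mg/kg (a lower number here means less inhibition, a higher number more inhibition at the dose given (going by the name of the read-out)), compound 3 stands second highest of the three: compound 1 lies a number 12 percentage points higher from compound 1 to compound 3 (beyond the scatter), while compound 2 lies a number 23 percentage points lower from compound 2 to compound 3 (beyond the scatter).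

Compound 4, `COc1cc2c(cc1OC)C(CC(=O)Nc1ccccc1C)CC2`, has not yet been measured. It differs from compound 3 in one place: 2-methylphenyl in place of 4-bromophenyl on an amide-type nitrogen.

Of the measured steps, two concern the aryl group as a whole: a number 35 percentage points higher from compound 1 to compound 2 (beyond the scatter) and a number 12 percentage points higher from compound 1 to compound 3 (beyond the scatter); the third, a number 23 percentage points lower from compound 2 to compound 3 (beyond the scatter), exchanges one halogen for another. None of them involves a methyl group or a 2-methylphenyl, so they bear on the new step only loosely. For the measured compounds named here, what they do show is that the aryl group matters, with swings beyond the scatter, and that the one compound whose aryl group is not a 4-halophenyl, compound 1, gives the lowest value among the three. Compound 4 also leaves the 4-halophenyl pattern, so a downward step is expected, a number 10 percentage points lower from compound 3 to compound 4 (within the scatter), though with wide uncertainty. For compound 4 the estimate in this assay is 30%, between 15% and 50%.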

Compound 4, a percentage reported as inhibition, in the whole organism at one dose (the size of the read-out at that dose, not a potency): 18%
Beside the measured number, compound 4's estimate is 12 percentage points above it; low and high end bracket the measured number.
By their numbers in this assay, from the lowest: compounds 4 and 1 (each within the scatter of the next); then compound 3; then compound 2.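

In this assay, putting 2-methylphenyl on the amide-type nitrogen costs much of the effect seen with the two 4-halophenyl groups: the number falls, a number 22 percentage points lower from compound 3 to compound 4 (beyond the scatter) and a number 45 percentage points lower from compound 2 to compound 4 (beyond the scatter). Against the 3-chlorophenyl group the picture is different, a number 10 percentage points lower from compound 1 to compound 4 (within the scatter), so these two aryl groups cannot be told apart here, and among the four compounds the higher numbers belong only to 4-bromophenyl and 4-chlorophenyl. Nothing measured here explains why the aryl groups rank this way.

On these data alone, what a plain phenyl, a 4-methylphenyl or a 2-chlorophenyl would give on the same nitrogen stays open, so the effect of the methyl group cannot be separated from the effect of its place on the ring or from the loss of the halogen. Also open is whether an aryl group carrying an amine or a carboxylic acid could match compound 2 at 63%, and whether the order of these compounds would hold at other doses or times.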